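The compounds below may be only part of what the source reports. "The series", "measured", "known", "first", "only" and "open" are said of these compounds alone.

Compound 1 `C/C=C1/[C@H](O[C@@H]2O[C@H](COC(C)=O)[C@@H](OC(C)=O)[C@H](OC(C)=O)[C@H]2OC(C)=O)OC=C(C(=O)OC)[C@H]1CC(=O)OCCC` gives 6600 nM in a functional assay on SK-BR-3 cells (Homo sapiens) for antiproliferative activity, read by MTT assay, with a stated time of 72 h; on this read-out higher numbers stand for weaker inhibition and lower numbers for stronger inhibition. Compound 2 `C/C=C1/[C@H](O[C@@H]2O[C@H](CO)[C@@H](O)[C@H](O)[C@H]2O)OC=C(C(=O)OC)[C@H]1CC(=O)OCCc1ccc(OC)c(OC)c1` is reported in this assay only as a limit, > 15000 nM. Compound 3 `C=CCOC(=O)C[C@@H]1C(C(=O)OC)=CO[C@@H](O[C@@H]2O[C@H](COC(C)=O)[C@@H](OC(C)=O)[C@H](OC(C)=O)[C@H]2OC(C)=O)/C1=C/C` is likewise reported only as a limit, > 20000 nM. Compound 2 therefore stands at a limit rather than at a number (the limit of > 15000 nM in this assay, at which 1 of the 3 values shown sits).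

Compound 4 `C/C=C1/[C@H](O[C@@H]2O[C@H](CO)[C@@H](O)[C@H](O)[C@H]2O)OC=C(C(=O)OC)[C@H]1CC(=O)OCCCC` differs from compound 2 by ethyl in place of 3,4-dimethoxyphenyl on a saturated chain carbon, two bonds along the chain from an oxygen next to a carbonyl group. Within the data shown here, no measured step covers this change; the one step known, an at least 3.0-fold higher number from compound 1 to compound 3 (0.48 log units; beyond the scatter), concerns the same ester chain and shows that changing it can move the number. Since compound 2 is at a limit, the direction of the change to compound 4 cannot be fixed from the numbers. Compound 4 is expected at 12000 nM, with a range from 4000 nM to 40000 nM. This corresponds to an expected step of an at least 1.2-fold lower number from compound 2 to compound 4 (0.09 log units; that floor lies within the scatter).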

Compound 4, half-maximal inhibitory concentration: > 15000 nM
Compound 4 was reported as a limit; the forecaster's own chance of this, stated with the estimate: 50%; middle value at least 1.2-fold (0.09 log units) from the limit.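

In this assay, among these compounds, compound 4 gives only a limit, > 15000 nM; compound 2 is also a limit, so no step between the two can be read. The compounds shown leave open whether ethyl in place of 3,4-dimethoxyphenyl changes the activity at all.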